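Notes on replacing the chain-end group

The source may report more compounds than this note shows. Statements on the series, on what has been measured and on what is new or still open speak of the compounds shown alone.

Within the data shown here, compound 1 (`CCN(CC)CCCCN(C[C@H]1Cc2ncccc2CN1)[C@H]1CCCc2cccnc21`) reads 3 nm/s in an ADME assay for permeability, using PAMPA, with a stated time of 4 h, at pH 5.5 (on this read-out higher numbers stand for higher permeability and lower numbers for lower permeability), and compound 2 (`CN(CCCCN(C[C@H]1Cc2ncccc2CN1)[C@H]1CCCc2cccnc21)C1CCC(F)(F)CC1`) reads 15 nm/s there, the higher of the two numbers so far. Compound 3 (`c1cnc2c(c1)CN[C@@H](CN(CCCCNC1CCOCC1)[C@H]1CCCc3cccnc31)C2`) is still unmeasured. Its difference from compound 2 is a group of 7 heavy atoms (5 carbon, 1 nitrogen, 1 oxygen; one six-membered non-aromatic ring with 1 hetero atom) in place of a group of 10 heavy atoms (7 carbon, 1 nitrogen, 2 fluorine; one six-membered non-aromatic ring of carbon only), on a saturated chain carbon, four bonds along the chain from an amine nitrogen and the entering group is (oxan-4-yl)amino, on a saturated chain carbon, four bonds along the chain from an amine nitrogen.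

Among the measured compounds shown here, one measured step bears on this place: a 5.0-fold higher number from compound 1 to compound 2 (0.70 log units; beyond the scatter) is modest and beyond the scatter, and there the larger group came with the higher number. For the measured compounds named here, that single step is thin evidence, and no measured step covers an entering group with a hydrogen-bond donor. With a smaller group now entering, a modest fall in this assay is expected, resting on a 5.0-fold higher number from compound 1 to compound 2 (0.70 log units; beyond the scatter) read in reverse. The expected change is a 3.0-fold lower number from compound 2 to compound 3 (0.48 log units; beyond the scatter) and it remains uncertain. The estimated value for compound 3 is 5 nm/s with an expected range from 2 nm/s to 14 nm/s in this read-out.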

Compound 3, apparent permeability: 2 nm/s
Beside the measured number, compound 3's estimate is 2.5-fold (0.40 log units) above it, and the stated range covers the measured number.
By their numbers in this assay, from the lowest: compounds 3 and 1 (each within the scatter of the next); then compound 2.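

In this assay, among these compounds, the step from the difluorinated ring group to (oxan-4-yl)amino, on a saturated chain carbon, four bonds along the chain from an amine nitrogen, gives a 7.5-fold lower number from compound 2 to compound 3 (0.88 log units; beyond the scatter), and this is the first measured step at this place in which the entering group carries a hydrogen-bond donor. Set against diethylamino, the same group gives a 1.5-fold lower number from compound 1 to compound 3 (0.18 log units; within the scatter), so the read-out does not separate these two groups despite their different make-up, and among the three compounds only compound 2 stands clear of the others. No measurement in hand offers an explanation for either result.

The step to compound 3 alters ring content, hetero atoms, donor count and group size together, and the compounds shown do not tell these apart. On these data alone, an N-methyl (oxan-4-yl)amino group would keep the oxygen-containing ring without the donor, and a cyclohexylamino group would keep the donor on a ring of carbon only, so the contribution of each feature at this place remains open.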